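The source may report more compounds than this note shows. Statements on the series, on what has been measured and on what is new or still open speak of the compounds shown alone.

Working notes, series around the shared core of compound 3 `COc1cc(-c2nn(-c3cccc(NC(=O)Nc4ccc(Cl)c(C(F)(F)F)c4)c3)cc2-c2ccncc2)ccc1Cl`. In a functional assay on OVCAR-3 cells (Homo sapiens) for inhibition, read by sulforhodamine B assay, with a stated time of 48 h (on this read-out higher numbers stand for weaker inhibition of growth and lower numbers for stronger inhibition of growth), compound 3 gives 2440 nM. Compound 2 `O=C(Nc1cccc(-n2cc(-c3ccncc3)c(-c3ccc(Cl)c(O)c3)n2)c1)Nc1ccc(Cl)c(Cl)c1` gives 3150 nM, which is within the scatter of compound 3; compound 1 `O=C(Nc1cccc(-n2cc(-c3ccncc3)c(-c3ccc(Cl)c(O)c3)n2)c1)Nc1cccc(C(F)(F)F)c1` gives 6130 nM, a higher number beyond the scatter. Within the data shown here, the one single-point step so far is a 1.9-fold lower number from compound 1 to compound 2 (0.29 log units; within the scatter), a change on the amide-type nitrogen.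

Compound 4 `O=C(Nc1cccc(-n2cc(-c3ccncc3)c(-c3ccc(Cl)c(O)c3)n2)c1)Nc1ccc(Cl)c(C(F)(F)F)c1` differs from compound 3 by hydrogen in place of methyl on an oxygen on an aromatic ring. Among the measured compounds shown here, no measured pair isolates this change; the step from compound 1 to compound 2 bears on it only indirectly, in that compounds 1 and 2 carry the hydroxy that compound 4 carries, and their numbers sit near or above that of compound 3. For the measured compounds named here, with no direct precedent, the step from compound 3 to compound 4 is expected to be a 1.4-fold higher number from compound 3 to compound 4 (0.16 log units; within the scatter), not beyond the scatter. Compound 4 is therefore estimated at 3500 nM, with a range from 1500 nM to 8000 nM.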

Compound 4, concentration for total growth inhibition: 2090 nM
Compound 4: the middle estimate sits 1.7-fold (0.22 log units) above what was measured; low and high end bracket the measured number.
By their numbers in this assay, from the lowest: compounds 4, 3, 2 and 1 (each within the scatter of the next, the first and the last beyond it).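

In this assay, the methoxy to hydroxy change on the 4-chloro-3-methoxyphenyl group is now isolated, and a 1.2-fold lower number from compound 3 to compound 4 (0.07 log units; within the scatter) gives no distinction between the two groups on this oxygen. Among these compounds, with the hydroxy held constant, trifluoromethyl in place of chloro on an aromatic carbon gives a 1.5-fold lower number from compound 2 to compound 4 (0.18 log units; within the scatter), while chloro in place of hydrogen on an aromatic carbon gives a 2.9-fold lower number from compound 1 to compound 4 (0.47 log units; beyond the scatter), the only one of these three steps beyond the scatter. Nothing available bears on the reason for the size of these steps.

The compounds shown leave open whether an ethoxy or a longer chain on this oxygen, or an amine in place of the hydroxy, would stay within the scatter of compound 4. They also leave open what replacing the chloro on this ring with fluoro or hydrogen would do, as all four compounds carry that chloro.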